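From Methoxy to Bromo at the Weak End

This account rests on a few compounds, and the source may have more. Where it says the series, first, only, none or still open, it means among the compounds named here.

In a functional assay on HCT-116 cells (Homo sapiens) for antiproliferative activity, read by MTT assay, with a stated time of 72 h (a lower number here means a stronger inhibitor, a higher number a weaker inhibitor), compound 1 `COc1ccc(-c2cnc3scc(C(=O)NNC(C)=O)n23)cc1` gives 17000 nM, compound 2 `CCC(=O)NNC(=O)c1csc2ncc(-c3ccc(OC)cc3)n12` gives 64300 nM and compound 3 `CCCC(=O)NNC(=O)c1csc2ncc(-c3ccc(OC)cc3)n12` gives 59100 nM. Compound 2 thus sits level with compound 3 at the weak end, and compound 1 stands lower. Compound 4 `CCC(=O)NNC(=O)c1csc2ncc(-c3ccc(Br)cc3)n12` replaces the 4-methoxyphenyl of compound 2 with 4-bromophenyl: bromo in place of methoxy on an aromatic carbon. Among the measured compounds shown here, no measured step touches this place. The measured steps all alter the saturated chain, giving a 3.8-fold higher number from compound 1 to compound 2 (0.58 log units; beyond the scatter) and a 1.1-fold lower number from compound 2 to compound 3 (0.04 log units; within the scatter), so they indicate only how far this small series has moved in this assay. With nothing closer to go on, the expected change is small: a 1.4-fold lower number from compound 2 to compound 4 (0.15 log units; within the scatter). Compound 4 is estimated at 45000 nM, with an expected range of 15000 nM to 100000 nM.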

Compound 4, half-maximal inhibitory concentration: 25300 nM
For compound 4 the middle estimate is 1.8-fold (0.25 log units) above the measured one; low and high end bracket the measured number.
By their numbers in this assay, from the lowest: compounds 1 and 4 (each within the scatter of the next); then compounds 3 and 2 (each within the scatter of the next).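

The change from 4-methoxyphenyl to 4-bromophenyl gives a 2.5-fold lower number from compound 2 to compound 4 (0.41 log units; beyond the scatter), which shows that this aromatic carbon, untouched by the earlier chain changes, also affects the number in this assay. The step is modest, but it lies beyond the usual scatter. Nothing available here gives a cause for this shift.

Open, going by these compounds, is how other groups at this place, such as chloro, an amine or a carboxylic acid, would compare. Also open, on these data alone, is whether bromo would give a similar step on the chains of compound 1 and compound 3.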